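Removing a Methyl from a Ring Oxygen

A few compounds are considered here, and "the series" means these few. Any claim that something is new, unique, unknown or untested is made for them only; others in the source may bear on it.

Compound 1 `COc1cc(/C=N/NC(=O)OCc2ccccc2)cc(OC)c1O` and compound 2 `COc1cc(/C=N/NC(=O)OCc2ccccc2)cc(OC)c1OC` share a core and differ in one place. In a physicochemical assay, read by spectrophotometry (on this read-out higher numbers stand for weaker inhibition and lower numbers for stronger inhibition), compound 1 gives 60500 nM. For compound 2 this assay reports only a limit, > 1000000 nM (the limit of > 1000000 nM in this assay, at which 1 of the 3 values shown sits). The change between them, (hydrogen in place of methyl on an oxygen on an aromatic ring), brings an at least 16-fold lower number from compound 2 to compound 1 (1.21 log units; beyond the scatter). Compound 3 `COc1cc(/C=N/NC(=O)OCc2ccccc2)ccc1O` gives 39700 nM in this assay, and the two numbers sit close: a 1.5-fold lower number from compound 1 to compound 3 (0.18 log units; within the scatter). The difference between the core of compound 3 and the core of compound 2 is not broken down here. Compound 4 `O=C(N/N=C/c1ccc(O)c(O)c1)OCc1ccccc1` has not yet been measured; it differs from compound 3 by hydrogen in place of methyl on an oxygen on an aromatic ring, the same change as that between compound 2 and compound 1, at the same place. Because the earlier step was an at least 16-fold lower number from compound 2 to compound 1 (1.21 log units; beyond the scatter), a step in the same direction is expected here, a 5.0-fold lower number from compound 3 to compound 4 (0.70 log units; beyond the scatter), though the earlier starting value is a limit and so the true size of that step is not known. Compound 4 is expected to give about 8000 nM in this assay, between 1500 nM and 40000 nM.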

Compound 4, half-maximal inhibitory concentration: 7300 nM
Compound 4: middle estimate off by 1.1-fold (0.04 log units), on the high side; the measured number falls inside the stated range.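

On the core of compound 3, putting hydroxy in place of methoxy again goes with a lower number and so with stronger inhibition in this assay (a 5.4-fold lower number from compound 3 to compound 4 (0.74 log units; beyond the scatter)), a step beyond the scatter and in the same direction as the step on the first core (an at least 16-fold lower number from compound 2 to compound 1 (1.21 log units; beyond the scatter)). This shows that the direction of the change carried over in these two pairs, but two pairs say nothing about how it would behave on any other core in the series. Whether the step has the same size on both cores cannot be read, because compound 2 has a limit and not a number: the limit of > 1000000 nM in this assay, at which 1 of the 4 values shown sits.

The compounds shown carry only a hydrogen or a methyl on this oxygen, so it remains open how a longer chain, such as ethyl, would fare there. From the compounds shown here alone, it is also open whether an amine or a carboxylic acid could stand in for the hydroxy at the same place.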